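A few compounds are considered here, and "the series" means these few. Any claim that something is new, unique, unknown or untested is made for them only; others in the source may bear on it.

Three compounds have been measured so far:
compound 1, `O=C(COCc1ccccc1)N1CCN(c2cccc(Cl)c2)CC1`: 6700 nM
compound 2, `O=C(COCc1ccccn1)N1CCN(c2ccc(Cl)cc2Cl)CC1`: 310 nM
compound 3, `O=C(COCc1ccncc1)N1CCC(c2ccc(Cl)cc2Cl)CC1`: 390 nM

These numbers come from a functional assay on HEK293 cells for positive allosteric modulation of metabotropic glutamate receptor 5 (Homo sapiens), read by FLIPR and calcium flux; a lower number here means that less compound is needed, a higher number that more compound is needed for the effect. Among the three, compound 2 has the lowest number. Compound 3 sits close by, within the usual scatter, so the two cannot be ranked against each other. Compound 1 lies well beyond the scatter from compound 2 and needs much more compound for the same effect.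

Compound 4, `O=C(CSc1ccccc1)N1CCN(c2ccc(Cl)cc2Cl)CC1`, has not been measured. It differs from compound 2 in a single place: phenylsulfanyl in place of (pyridin-2-yl)methoxy on a saturated chain carbon bound to a carbonyl carbon. For the measured compounds named here, no measured pair shows this change, so no directly comparable step exists, and the expectation below rests only on compound 2 and on the change itself. The step of a 2.6-fold higher number from compound 2 to compound 4 (0.41 log units; beyond the scatter) is expected to be a modest rise in the number, only a little beyond the scatter, with the direction itself uncertain. For compound 4 the expected value in this assay is 800 nM, with a range from 250 nM to 3000 nM.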

Compound 4, half-maximal effective concentration: > 25000 nM
Compound 4 ended at the assay's limit; the forecaster's own chance of this, stated with the estimate: 10%; at least 31-fold (1.49 log units) between middle value and limit.
By their numbers in this assay, from the lowest: compounds 2 and 3 (each within the scatter of the next); then compound 1. At a limit, above all of these: compound 4.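

On a saturated chain carbon bound to a carbonyl carbon, phenylsulfanyl in place of (pyridin-2-yl)methoxy gives an at least 80-fold higher number from compound 2 to compound 4 (1.90 log units; beyond the scatter) in this assay. For the compounds shown here, no earlier pair differed in only one place, so this is the first sign that a single change here can move the number by far more than the scatter. The result for compound 4 is a limit of the assay and not a number, so the step has no known upper end: the limit of > 25000 nM in this assay, at which 1 of the 4 values shown sits.

The change alters several things at once, including the nitrogen in the ring, oxygen against sulfur and the heavy atom count of the group, and the compounds shown cannot tell which of these matters. A phenoxy or a (pyridin-2-yl)sulfanyl group at this place would help to separate them.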